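Sulfonyl for Sulfanyl: Expecting Compound 4

The source may hold more compounds than are shown below. What is called first, only, known or untested is meant among the compounds shown, and "the series" means these compounds.

Three compounds set the scene. Compound 1 `O=C(/C(=C\c1ccccc1OCc1ccccc1)SCc1ccc(F)cc1)c1ccc(Cl)cc1` gives 1000 nM in a functional assay on DU-145 cells (Homo sapiens) for inhibition, read by trypan blue exclusion, with a stated time of 96 h (a lower number here means a stronger inhibitor of growth, a higher number a weaker inhibitor of growth), and compound 2 `O=C(/C(=C\c1ccc(Br)cc1)Sc1ccccc1Br)c1ccc(Br)cc1` gives 1000 nM. Compound 3 `COc1ccccc1/C=C(/SCc1ccc(F)cc1)C(=O)c1ccc(Cl)cc1` gives 10000 nM. For the measured compounds named here, on these numbers compound 1 stands level with compound 2 at the digits printed, the two together the lowest of the three, with compound 3 the furthest away; the one measured step, a 10-fold higher number from compound 1 to compound 3 (1.00 log units; beyond the scatter), came from hydrogen in place of phenyl on a saturated chain carbon bound to an oxygen on an aromatic ring.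

Compound 4 `O=C(/C(=C\c1ccccc1OCc1ccccc1)S(=O)(=O)c1ccc(Br)cc1)c1ccc(Cl)cc1` differs from compound 1 by (4-bromophenyl)sulfonyl in place of (4-fluorobenzyl)sulfanyl on a double-bonded chain carbon bound to a carbonyl carbon and a double-bonded chain carbon. Going by the values given here, no measured step touches this place; the step from compound 1 to compound 3 changes a different part of the molecule, and the pair of compound 1 and compound 2 shows only that two sulfanyl groups of different kind give values within the scatter of each other. Among the compounds with values here, the data therefore offer no step of the same kind to lean on, and the expectation must stay wide.

He expects compound 4 to lie somewhat weaker than compound 1, a step of a 2.5-fold higher number from compound 1 to compound 4 (0.40 log units; beyond the scatter), and estimates for compound 4 a value of 2500 nM, within a range from 600 nM to 12000 nM.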

Compound 4, concentration for 50% growth inhibition: 1000 nM
Compound 4: middle estimate off by 2.5-fold (0.40 log units), on the high side, and the stated range covers the measured number.
By their numbers in this assay, from the lowest: compounds 1, 2 and 4 (each within the scatter of the next); then compound 3.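

For the compounds shown here, at the double-bonded chain carbon bound to a carbonyl carbon and a double-bonded chain carbon, which no earlier step had touched, (4-bromophenyl)sulfonyl in place of (4-fluorobenzyl)sulfanyl gives no change at the digits printed from compound 1 to compound 4 (within the scatter) in this assay. This place therefore accepts a sulfonyl group carrying a different aromatic ring with no change beyond the scatter, whereas the change on the saturated chain carbon bound to an oxygen on an aromatic ring gave a 10-fold higher number from compound 1 to compound 3 (1.00 log units; beyond the scatter). The exchange alters the sulfur, the link to the ring and the halogen in a single step, and nothing available accounts for the unchanged number.

The compounds shown leave open how each part of the exchange acts alone, as (4-fluorobenzyl)sulfonyl and (4-bromophenyl)sulfanyl would separate the sulfur from the aromatic group that it carries. They also leave open whether hydrogen in place of phenyl would bring the same step to compound 4, and whether this place would accept an amine or a carboxylic acid instead of an aromatic group.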